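The source may report more compounds than this note shows. Statements on the series, on what has been measured and on what is new or still open speak of the compounds shown alone.

Measured so far in a physicochemical assay for solubility, at pH 6.5; on this read-out lower numbers stand for lower solubility and higher numbers for higher solubility:
Compound 1 `N[C@@H](CSNC(=O)[C@@H](CCC(F)(F)F)N(Cc1ccc(-c2ncon2)cc1F)S(=O)(=O)c1ccc(Cl)cc1)C(=O)O` gives 260 ug/mL.
Compound 2 `N#CCCSNC(=O)[C@@H](CCC(F)(F)F)N(Cc1ccc(-c2ncon2)cc1F)S(=O)(=O)c1ccc(Cl)cc1` reaches only a limit in this assay, reported as < 1 ug/mL.

Compound 2 therefore stands at the bottom of the data shown; its value is a limit, not a number, and the limit of < 1 ug/mL in this assay, at which 1 of the 2 values shown sits, describes that situation. For the measured compounds named here, the only step measured so far is an at least 260-fold lower number from compound 1 to compound 2 (2.41 log units; beyond the scatter), which removed the amino(carboxy)methyl group in favour of a cyanomethyl group and dropped the read-out to the limit.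

Compound 3 `CCOC(=O)[C@@H](N)CSNC(=O)[C@@H](CCC(F)(F)F)N(Cc1ccc(-c2ncon2)cc1F)S(=O)(=O)c1ccc(Cl)cc1` differs from compound 2 in one place: amino(ethoxycarbonyl)methyl in place of cyanomethyl on a saturated chain carbon bound to a sulfur. The change reinstates most of what compound 1 carries, with an ethoxycarbonyl in place of the carboxy. Given the size of the step from compound 1 to compound 2, a return partway toward compound 1 is expected; the ester is not the acid, so a full return is not assumed. The step from compound 2 to compound 3 is expected to be a clear rise, an at least 30-fold higher number from compound 2 to compound 3 (1.47 log units; beyond the scatter), and compound 3 is estimated at 30 ug/mL with a range from 3 ug/mL to 150 ug/mL.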

Compound 3, solubility: 10 ug/mL
Compound 3: middle estimate off by 3.0-fold (0.48 log units), on the high side; the measured number falls inside the stated range.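

In this assay, amino(ethoxycarbonyl)methyl on a saturated chain carbon bound to a sulfur gives a measurable read-out where cyanomethyl did not, and the carboxy group is not required for that: an at least 10-fold higher number from compound 2 to compound 3 (1.00 log units; beyond the scatter). That step gives only a minimum size, as compound 2 stands at a limit of the assay and not at a number: the limit of < 1 ug/mL in this assay, at which 1 of the 3 values shown sits. With the amino group kept in both compounds, ethyl in place of hydrogen on an oxygen next to a carbonyl group is itself a large change, a 26-fold lower number from compound 1 to compound 3 (1.41 log units; beyond the scatter), so the difference between the carboxy group and its ethyl ester can now be read on its own, without a limit involved.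

The compounds shown leave open how much of the rise from the limit belongs to the amine and how much to the ester or acid part, as these two parts always appear together here. A 2-aminoethyl or a 2-carboxyethyl group in place of the 2-cyanoethyl would separate them, and a methyl ester would show whether the length of the ester chain matters.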